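Replacing 2-chlorophenyl with quinolin-2-yl on the carbonyl carbon

The source may hold more compounds than are shown below. What is called first, only, known or untested is meant among the compounds shown, and "the series" means these compounds.

Compound 1 `CCN1CCN(c2cc(C)c3cc(NC(=O)c4ccc(F)c(F)c4)ccc3n2)CC1`: 1980 nM
Compound 2 `CCN1CCN(c2cc(C)c3cc(NC(=O)c4ccccc4Cl)ccc3n2)CC1`: > 50000 nM

Both compounds were tested in a functional assay on SK-BR-3 cells (Homo sapiens) for antiproliferative activity, read by MTT assay, with a stated time of 72 h; a higher number here means a weaker inhibitor, a lower number a stronger inhibitor. For compound 2 the entry > 50000 nM is a limit of the assay and not a number. Compound 2 thus stands at the limit of > 50000 nM in this assay, at which 1 of the 2 values shown sits.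

Compound 3 `CCN1CCN(c2cc(C)c3cc(NC(=O)c4ccc5ccccc5n4)ccc3n2)CC1` is still unmeasured. It carries quinolin-2-yl in place of 2-chlorophenyl on a carbonyl carbon.

Among the measured compounds shown here, the one measured step at this place is an at least 25-fold higher number from compound 1 to compound 2 (1.40 log units; beyond the scatter), a large step that involves neither group entering here. It shows that exchanging this group can move the result far, and compound 1 at 1980 nM shows that a measurable number is within reach. A sizeable move towards a lower number is therefore expected in this assay, though compound 3 could also stay at the limit. The estimated step is an at least 4.1-fold lower number from compound 2 to compound 3 (0.61 log units; beyond the scatter). For compound 3 the estimate is 12000 nM, with an expected range from 2500 nM to 50000 nM.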

Compound 3, half-maximal inhibitory concentration: 3760 nM
Compound 3: middle estimate off by 3.2-fold (0.50 log units), on the high side; the measured number falls inside the stated range.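

In this assay, quinolin-2-yl on the carbonyl carbon restores a measurable number, with an at least 13-fold lower number from compound 2 to compound 3 (1.12 log units; beyond the scatter), so the inactivity of compound 2 does not extend to every replacement of 3,4-difluorophenyl at this place. That step has only a lower bound, since compound 2 carries a limit and not a number: the limit of > 50000 nM in this assay, at which 1 of the 3 values shown sits. The comparison with the difluorinated amide adds that a two-ring group with one ring nitrogen is accepted here, as a 1.9-fold higher number from compound 1 to compound 3 (0.28 log units; within the scatter), leaving quinolin-2-yl and 3,4-difluorophenyl indistinguishable in this assay.

The compounds shown do not separate the contribution of the ring nitrogen from that of the second ring, nor show whether losing the chlorine alone would restore activity. Unsubstituted phenyl, pyridin-2-yl and naphthalen-2-yl on the same carbonyl carbon would each address part of that question.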